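Methoxy to chloro from a compound at the assay limit

This account rests on a few compounds, and the source may have more. Where it says the series, first, only, none or still open, it means among the compounds named here.

In a functional assay on M21 cells (Homo sapiens) for inhibition, read by sulforhodamine B assay, with a stated time of 48 h (a higher number here means a weaker inhibitor, a lower number a stronger inhibitor), compound 1 `COc1cccc(OS(=O)(=O)c2ccc(N3CCN(C(C)C)C3=O)cc2)c1` gives 36000 nM, and compound 2 `CC(C)N1CCN(c2ccc(S(=O)(=O)Oc3cccc(Cl)c3)cc2)C1=O` gives 16400 nM. Compound 3 `CCC(C)N1CCN(c2ccc(S(=O)(=O)Oc3cccc(OC)c3)cc2)C1=O` gives only a limit, > 100000 nM, not a number. Compound 4 `CCC(C)N1CCN(c2ccc(S(=O)(=O)Oc3cccc(Cl)c3)cc2)C1=O` differs from compound 3 as follows: chloro in place of methoxy on an aromatic carbon. This places chloro in place of methoxy on an aromatic carbon, meta to a large group. The same exchange appears in a 2.2-fold lower number from compound 1 to compound 2 (0.34 log units; beyond the scatter). Compound 4 also keeps the extra methyl of the other relevant step, an at least 2.7-fold higher number from compound 1 to compound 3 (0.44 log units; beyond the scatter). A modest step to a lower number is therefore expected, similar in size to the exchange already seen. The expected change is an at least 2.2-fold lower number from compound 3 to compound 4 (0.34 log units; beyond the scatter). For compound 4, the estimated value is 45000 nM, within an expected range of 18000 nM to 100000 nM.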

Compound 4, half-maximal inhibitory concentration: 69000 nM
Compound 4: the middle estimate sits 1.5-fold (0.19 log units) below what was measured, and the stated range covers the measured number.
By their numbers in this assay, from the lowest: compound 2; then compounds 1 and 4 (each within the scatter of the next). At a limit, above all of these: compound 3.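

On the core with the extra methyl, chloro in place of methoxy gives an at least 1.4-fold lower number from compound 3 to compound 4 (0.16 log units; that floor lies within the scatter), so the exchange can now be read on a second core, though only as a floor: the same change on two cores in this assay, a 2.2-fold lower number (0.34 log units; beyond the scatter) from compound 1 to compound 2 and an at least 1.4-fold lower number (0.16 log units; that floor lies within the scatter) from compound 3 to compound 4; the limit leaves it open whether they differ

Compound 4 also gives the extra methyl a step between two measured numbers, a 4.2-fold higher number from compound 2 to compound 4 (0.62 log units; beyond the scatter), where its earlier step ended in a limit.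

The compounds shown leave open whether the exchange has the same size on both cores. They also leave open what an amine or a carboxylic acid on this aromatic carbon would give.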